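Adding a methyl to compound 3

The compounds below may be only part of what the source reports. "The series", "measured", "known", "first", "only" and "open" are said of these compounds alone.

In an ADME assay on MT4 cells (Homo sapiens) for cytotoxicity, read by MTT assay (on this read-out lower numbers stand for higher toxicity in this test and higher numbers for lower toxicity in this test), the three measured compounds all end at limits, and none gives a number. Compound 1 (`COc1ccc(CCSc2nc(Cc3c(Cl)cccc3Cl)c(C)c(=O)[nH]2)cc1`) reads > 57000 nM as a limit. Compound 2 (`O=C(CSc1nc(Cc2c(Cl)cccc2Cl)cc(=O)[nH]1)c1ccccc1`) reads > 12000 nM as a limit. Compound 3 (`O=C(CSc1nc(Cc2c(Cl)cccc2Cl)cc(=O)[nH]1)c1ccc(F)cc1`) reads > 59000 nM as a limit, so it can be placed only alongside the other two.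

Compound 4 (`Cc1c(Cc2c(Cl)cccc2Cl)nc(SCC(=O)c2ccc(F)cc2)[nH]c1=O`) differs from compound 3 in one place: methyl in place of hydrogen on an aromatic carbon and the methyl takes the place of hydrogen on an aromatic carbon, ortho to a 2,6-dichlorobenzyl group. Within the data shown here, no measured step shows this change directly. Among the measured compounds shown here, the one measured step is a step that the two limits leave unreadable from compound 2 to compound 3 and it is a different change, fluoro in place of hydrogen on an aromatic carbon, so it offers no size to carry over. Compound 1 also carries a methyl on the shared core and still reads > 57000 nM as a limit.

On that evidence no step beyond the scatter is expected in this assay and no direction is favoured, and a further limit is the likeliest report. The expected step is an at least 1.0-fold lower number from compound 3 to compound 4 (0.03 log units; that floor lies within the scatter) and it rests on limits alone. For compound 4 the estimate is 55000 nM with an expected range from 12000 nM to 120000 nM as its ends.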

Compound 4, half-maximal cytotoxic concentration: > 57000 nM
Compound 4 gave a limit, no number (the forecaster's own chance of this, stated with the estimate: 80%); at least 1.0-fold (0.01 log units) between middle value and limit.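

Compound 4 ends at a limit in this assay, as compound 1 and compound 3 do, so neither the step from compound 3 to compound 4 nor the step from compound 1 to compound 4 can be read. The compounds shown leave open how far the methyl in place of hydrogen moves this read-out, and in which direction.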